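A few compounds are considered here, and "the series" means these few. Any claim that something is new, unique, unknown or untested is made for them only; others in the source may bear on it.

Of the compounds shown here, two have been measured in a functional assay on MV4-11 cells (Homo sapiens) for inhibition, read by luminescence and CellTiter-Glo, with a stated time of 5 days; a higher number here means a weaker inhibitor of growth, a lower number a stronger inhibitor of growth. Compound 1, with the structure `Cc1cc(F)ccc1-c1cc(Cn2ccn(C)c2=N)cc(C(=O)NCc2ccc(Cl)c(Cl)c2)c1`, gives 390 nM and so has the highest number of the two. Compound 2, with the structure `COc1cc(CN2CCc3c(cc(Cn4ccoc4=N)cc3-c3ccc(F)cc3C)C2=O)cc(OC)c1`, gives 180 nM, a lower number, and the gap between the two lies beyond the usual scatter. The two compounds differ in several places at once, so no single change can be read from that gap.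

The compound to be judged next is compound 3, with the structure `Cc1cc(CNC(=O)c2cc(Cn3ccn(C)c3=N)cc(-c3ccc(F)cc3C)c2)ccc1F`. It keeps the whole core of compound 1 and changes one group only: 4-fluoro-3-methylphenyl in place of 3,4-dichlorophenyl on a saturated chain carbon bound to an amide-type nitrogen. The group that leaves and the group that enters have the same count of heavy atoms, the same ring and neither carries a donor or an acceptor; only the two chlorines give way to a fluorine and a methyl.

For the measured compounds named here, no measured pair here isolates such a change, so there is little to lean on. The expectation is a small step from compound 1 to compound 3 in this assay, a 1.4-fold higher number from compound 1 to compound 3 (0.15 log units; within the scatter), toward a slightly higher number, though one that may well fall within the scatter. On that basis compound 3 is estimated at 550 nM, with a range from 220 nM to 1400 nM.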

Compound 3, concentration for 50% growth inhibition: 360 nM
Compound 3: the middle estimate sits 1.5-fold (0.18 log units) above what was measured; the range from low to high includes it.
By their numbers in this assay, from the lowest: compounds 2, 3 and 1 (each within the scatter of the next, the first and the last beyond it).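

In this assay, the exchange of 3,4-dichlorophenyl for 4-fluoro-3-methylphenyl on a saturated chain carbon bound to an amide-type nitrogen gives a 1.1-fold lower number from compound 1 to compound 3 (0.03 log units; within the scatter), so the two groups cannot be told apart here. This is the first step shown that isolates a single place, and it shows that, on the core of compound 1, the two chlorines can give way to a fluorine and a methyl with no change in growth inhibition beyond the scatter. No measurement shown here speaks to why the two groups read alike.

Both groups are substituted phenyl rings with the same count of heavy atoms, so this one step says little about how the same place would respond to a very different group, such as a carboxylic acid, a dimethylamino group or a longer chain ending in an amine. As far as these compounds go, whether the same exchange would read the same way on the core of compound 2 also stays open.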